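This account rests on a few compounds, and the source may have more. Where it says the series, first, only, none or still open, it means among the compounds named here.

Compound 2 `CCCn1ccc2cc(-c3ccc(OC)cc3)cc(Cl)c2c1=O` and compound 1 `CCCn1ccc2cc(OCCCc3cccnc3)cc(Cl)c2c1=O` share one core and differ only in the group hanging from it. In a functional assay on CHO cells for agonist activity at metabotropic glutamate receptor 2 (Homo sapiens), read by GTPgammaS binding (a lower number here means that less compound is needed, a higher number that more compound is needed for the effect), compound 2 gives 316 nM. In this assay compound 1 gives 631 nM. Compound 2 has the lower of the two numbers, but its distance from compound 1 lies within the usual scatter of repeated measurements, so the two values cannot really be told apart. Compound 3 `CCCn1ccc2cc(-c3ccc(Oc4ccccc4)cc3)cc(Cl)c2c1=O` is built from compound 2 by a single change: phenyl in place of methyl on an oxygen on an aromatic ring. Seen from one bond further out, a methoxy group becomes a phenoxy group. Going by the values given here, no pair of measured compounds shows a change of this kind, so nothing measured says how large a step to expect or in which direction. Among the compounds with values here, with only two values in hand, the most defensible expectation is a step that stays inside the scatter, neither clearly up nor clearly down. The step from compound 2 to compound 3 is therefore expected to be a 1.3-fold lower number from compound 2 to compound 3 (0.10 log units; within the scatter). For compound 3 in this assay, the estimate is 250 nM, with a range from 60 nM to 1000 nM.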

Compound 3, half-maximal effective concentration: 2000 nM
The estimate for compound 3 lay 8.0-fold (0.90 log units) below the measured number, and the stated range ends below it.
By their numbers in this assay, from the lowest: compounds 2 and 1 (each within the scatter of the next); then compound 3.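

In this assay, putting phenyl in place of methyl on the oxygen gives a 6.3-fold higher number from compound 2 to compound 3 (0.80 log units; beyond the scatter) and so shows that this position does not treat all groups alike: here, more compound is needed for the effect. The oxygen and the rest of compound 2 stay as they are, so the step belongs to this one exchange, in which methyl with 1 heavy atom gives way to phenyl with 6 heavy atoms and a six-membered aromatic ring of carbon only, while neither group has a hydrogen-bond donor, a hydrogen-bond acceptor or a net charge. No measurement available here explains why this exchange raises the number.

A single step cannot separate the effect of the larger group from that of the ring itself: ethyl or a longer carbon chain on the same oxygen could show whether the number rises gradually or only once a ring is present. From the compounds shown here alone, it also remains open how a pyridine ring or an amine at this place would compare, and whether the same exchange would give a similar step on another core.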